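Amide swap on a shared core: toxicity expectation

The compounds below may be only part of what the source reports. "The series", "measured", "known", "first", "only" and "open" are said of these compounds alone.

Compound 1 `Cn1c(-c2ccc(C#N)cc2)cnc1NC(=O)c1ccc(F)cc1`: > 50000 nM
Compound 2 `COc1ccc(-c2cnc(NC(=O)c3cccc([N+](=O)[O-])c3)n2C)cc1`: > 100000 nM
Compound 3 `COc1ccc(-c2cnc(NC(=O)c3cccc(Br)c3)n2C)cc1`: > 100000 nM

Three compounds share one core and differ only in the group on the carbonyl carbon of the amide. In a toxicity assay on THP-1 cells (Homo sapiens) for inhibition (on this read-out higher numbers stand for lower toxicity in this test and lower numbers for higher toxicity in this test), compound 1 gives only a limit, > 50000 nM. In this assay compound 2 also gives a limit, > 100000 nM. Compound 3 stands at a limit as well, > 100000 nM, so no number places it against the other two. Within the data shown here, the one step between measured neighbours, a step that the two limits leave unreadable from compound 2 to compound 3, cannot be read because both of its ends sit at the limit of > 100000 nM in this assay, at which 2 of the 3 values shown sit.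

Compound 4 `COc1ccc(-c2cnc(NC(=O)C3CCNCC3)n2C)cc1` is not yet measured. It differs from compound 3 in one place: piperidin-4-yl in place of 3-bromophenyl on a carbonyl carbon. Among the measured compounds shown here, no measured step covers an exchange of an aromatic ring for a non-aromatic ring with one hetero atom on that carbonyl carbon, so the expectation rests only on where the three measured compounds sit: two at the limit of > 100000 nM in this assay, at which 2 of the 3 values shown sit, and one at the limit of > 50000 nM in this assay, at which 1 of the 3 values shown sits. Compound 4 is therefore expected to show no step beyond the scatter, a number no higher from compound 3 to compound 4 (the limit leaves the size open), and most likely another limit. The estimate for compound 4 in this assay is 100000 nM, with a range from 30000 nM to 300000 nM.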

Compound 4, half-maximal cytotoxic concentration: > 100000 nM
Compound 4: a limit, no number (the forecaster's own chance of this, stated with the estimate: 80%); the middle value lies on the limit itself.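

In this assay compound 4 gives > 100000 nM, a limit and not a number. Compound 3 also stands at a limit, so the step from compound 3 to compound 4 cannot be read. The compounds shown leave open whether the group on the carbonyl carbon changes the read-out in this assay at all, since none of them gives a number.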